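A few compounds are considered here, and "the series" means these few. Any claim that something is new, unique, unknown or untested is made for them only; others in the source may bear on it.

Of the compounds shown here, two have been measured in a functional assay on DU-145 cells (Homo sapiens) for cytotoxicity, read by MTT assay, with a stated time of 48 h (a higher number here means a weaker inhibitor, a lower number a stronger inhibitor), so far. Compound 1, with the structure `CC1(C)CCC[C@]1(C)c1ccc(C=O)cc1`, is a small aldehyde and gives 260000 nM in this assay. Compound 2, with the structure `C=C1CCC[C@]2(C)CCC(c3cn(-c4ccc(C(C)=O)cc4)nn3)=CC[C@@]12C`, carries a much larger core joined to a ring bearing an acetyl group, and in this assay compound 2 gives 51700 nM, the lower of the two numbers and beyond the scatter from compound 1.

Compound 3, with the structure `C=C1CCC[C@]2(C)CCC(c3cn(-c4ccc(I)cc4)nn3)=CC[C@@]12C`, has not yet been measured. It differs from compound 2 in one place: iodo in place of acetyl on an aromatic carbon. Going by the values given here, no measured pair shows what this kind of exchange does here, so the direction of the step is open. The step from compound 2 to compound 3 is expected to be small, a 1.5-fold lower number from compound 2 to compound 3 (0.17 log units; within the scatter), within or only just beyond the scatter. Compound 3 is therefore estimated to give about 35000 nM in this assay, with a range from 12000 nM to 100000 nM.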

Compound 3, half-maximal inhibitory concentration: 145000 nM
Beside the measured number, compound 3's estimate is 4.1-fold (0.62 log units) below it; the measured number lies above the stated range.
By their numbers in this assay, from the lowest: compound 2; then compounds 3 and 1 (each within the scatter of the next).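

Going by these compounds alone, the exchange of 4-acetylphenyl for 4-iodophenyl gives the first direct reading of this position in this assay: it brings a 2.8-fold higher number from compound 2 to compound 3 (0.45 log units; beyond the scatter). The rest of the molecule stays the same, so the group on this aromatic carbon does change the number, though only modestly, and of these two groups the acetyl gives the stronger inhibitor in this assay. Nothing measured here explains the size or direction of this step, and one pair of compounds cannot show which feature of the acetyl group matters.

On these data alone, it remains open whether an amine, a carboxylic acid or a methoxy group on this aromatic carbon would give a lower or a higher number than the acetyl group. A single pair also leaves open whether the same exchange would have a similar effect on a different core.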